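The compounds below may be only part of what the source reports. "The series", "measured", "known", "first", "only" and "open" are said of these compounds alone.

Compound 3 `O=c1cc(-c2cccs2)oc2ccc(OCCCCCCN3CCC(O)CC3)cc12`: in an assay on isolated protein (Cavia porcellus) with Sigma non-opioid intracellular receptor 1 (Homo sapiens) as the target, read by radioligand binding (a higher number here means a weaker inhibitor, a lower number a stronger inhibitor), compound 3 gives 232 nM
Compound 1 `CN(C)CCCCCCCCCOc1ccc2oc(-c3ccccc3)cc(=O)c2c1`: compound 1 gives 202 nM
Compound 2 `CN(CCCCCCOc1ccc2oc(-c3ccccc3)cc(=O)c2c1)Cc1ccccc1`: compound 2 gives 75 nM

Among these three, compound 3 and compound 1 lie within the scatter of each other, while compound 2 is separated from compound 3 by a gap beyond the scatter. Compound 4 `O=c1cc(-c2ccc(F)cc2)oc2ccc(OCCCCCCN3CCC(O)CC3)cc12` differs from compound 3 by 4-fluorophenyl in place of thiophen-2-yl on an aromatic carbon. Among the compounds with values here, no measured step touches this part of the molecule: the only measured step, a 2.7-fold lower number from compound 1 to compound 2 (0.43 log units; beyond the scatter), concerns a different region. Compounds 1 and 2 already carry a plain phenyl at this position, and compound 1 sits within the scatter of compound 3. Compound 4 is therefore expected to show no step beyond the scatter, a 1.2-fold lower number from compound 3 to compound 4 (0.06 log units; within the scatter). The estimate for compound 4 is 200 nM, with a range from 80 nM to 500 nM.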

Compound 4, half-maximal inhibitory concentration: 132 nM
Compound 4: middle estimate off by 1.5-fold (0.18 log units), on the high side; low and high end bracket the measured number.
By their numbers in this assay, from the lowest: compounds 2, 4, 1 and 3 (each within the scatter of the next, the first and the last beyond it).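

In this assay, within the data shown here, the first measured change at this position, on the aromatic carbon next to the ring oxygen, gives a 1.8-fold lower number from compound 3 to compound 4 (0.24 log units; within the scatter), so exchanging thiophen-2-yl for 4-fluorophenyl does not stand out from repeat-measurement noise. This single pair therefore shows that a five-membered aromatic ring containing sulfur and a fluorinated six-membered carbon ring can read alike here. Nothing available explains this similarity.

Still open, from the compounds shown here alone, is how a plain phenyl, a 4-chlorophenyl or a pyridin-3-yl would read here alongside the side chain of compound 3. Going by these compounds, the separate contribution of the fluorine also remains unknown.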